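Replacing the ethylpiperazine of compound 1 with an imidazole

A few compounds are considered here, and "the series" means these few. Any claim that something is new, unique, unknown or untested is made for them only; others in the source may bear on it.

Compound 1 `CCN1CCN(C[C@H]2CN(c3ccc(-n4cc(-c5ccccn5)cn4)c(F)c3)C(=O)O2)CC1` holds the highest of the three solubility numbers recorded here. In a physicochemical assay for solubility, read by HPLC, with a stated time of 24 h (a lower number here means a less soluble compound, a higher number a more soluble compound), compound 1 gives 706000 nM. Its nearest neighbour is compound 2 `CC(=O)OC[C@H]1CN(c2ccc(-n3cc(-c4ccccn4)cn3)c(F)c2)C(=O)O1`, which in this assay gives 373000 nM, a step of a 1.9-fold lower number from compound 1 to compound 2 (0.28 log units; within the scatter). The furthest is compound 3 `COC[C@H]1CN(c2ccc(-n3cc(-c4ccccn4)cn3)c(F)c2)C(=O)O1`, which gives 36200 nM, a step of a 20-fold lower number from compound 1 to compound 3 (1.29 log units; beyond the scatter); between those two, a 10-fold lower number from compound 2 to compound 3 (1.01 log units; beyond the scatter).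

The step now followed leads to compound 4 `O=C1O[C@@H](Cn2ccnc2)CN1c1ccc(-n2cc(-c3ccccn3)cn2)c(F)c1`, in which (1H-imidazol-1-yl in place of 4-ethylpiperazin-1-yl on a saturated chain carbon bound to a saturated ring carbon). The two steps that bear on it are the ones that also remove the 4-ethylpiperazin-1-yl from the same carbon of compound 1: the small one to compound 2 and the large one to compound 3. Both point downward, and the size depends strongly on what enters in its place. The imidazol-1-yl ring, carrying two hydrogen-bond acceptors and no donor, is neither of those groups, so the outcome is expected to fall somewhere between the two earlier steps, with a downward direction and a size that is probably beyond the scatter.

Compound 4 is therefore estimated at 150000 nM in this assay, within a range of 40000 nM to 500000 nM, which would be a step of a 4.7-fold lower number from compound 1 to compound 4 (0.67 log units; beyond the scatter).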

Compound 4, solubility: 12300 nM
Compound 4: the middle estimate sits 12-fold (1.09 log units) above what was measured; the whole stated range lies above it.
By their numbers in this assay, from the lowest: compound 4; then compound 3; then compounds 2 and 1 (each within the scatter of the next).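

In this assay, the 1H-imidazol-1-yl group on this saturated chain carbon gives the lowest number of the four compounds, with a 57-fold lower number from compound 1 to compound 4 (1.76 log units; beyond the scatter), and it also falls short of both smaller groups, with a 2.9-fold lower number from compound 3 to compound 4 (0.47 log units; beyond the scatter) and a 30-fold lower number from compound 2 to compound 4 (1.48 log units; beyond the scatter). The range of numbers at this position therefore reaches further down than the methoxy compound had shown, and the lowest number now belongs to a ring rather than to an open chain. The 4-ethylpiperazin-1-yl and the 1H-imidazol-1-yl count the same hydrogen-bond donors and acceptors and carry no net charge, so matching those counts did not keep the number up, though no measurement here bears on why the number fell.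

On these data alone, it remains open whether the low number follows the five-membered aromatic ring or the departure of the six-membered non-aromatic one. A 1H-pyrazol-1-yl or a 1,2,4-triazol-1-yl on the same carbon could speak to the first, and a morpholin-4-yl or a piperidin-1-yl to the second.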